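Bromo for Fluoro in a Lysosomal Glucosidase Series

The source may report more compounds than this note shows. Statements on the series, on what has been measured and on what is new or still open speak of the compounds shown alone.

Compound 1 `Cc1ccc(N2CCN(S(=O)(=O)c3ccc4c(c3)CC(=O)N4)CC2)cc1`: "not active" (no number reported)
Compound 2 `N#Cc1ccc(N2CCN(S(=O)(=O)c3ccc4c(c3)CC(=O)N4)CC2)cc1`: 3260 nM
Compound 3 `O=C1Cc2cc(S(=O)(=O)N3CCN(c4ccc(F)cc4)CC3)ccc2N1`: "not active" (no number reported)

Three compounds built on a shared core have been examined in an assay on isolated protein for inhibition of lysosomal alpha-glucosidase (Homo sapiens), read by fluorescence, with stated times of 5 min and 45 min; on this read-out higher numbers stand for weaker inhibition and lower numbers for stronger inhibition. Within the data shown here, compound 2 `N#Cc1ccc(N2CCN(S(=O)(=O)c3ccc4c(c3)CC(=O)N4)CC2)cc1` returns 3260 nM, the only measured number among the three. Compound 1 `Cc1ccc(N2CCN(S(=O)(=O)c3ccc4c(c3)CC(=O)N4)CC2)cc1` gives "not active" (no number reported) in this assay, and compound 3 `O=C1Cc2cc(S(=O)(=O)N3CCN(c4ccc(F)cc4)CC3)ccc2N1` likewise gives "not active" (no number reported). Compound 3 thus stands without a single number, a standing it shares with one further entry, compound 1; only compound 2 is placed on the scale.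

Compound 4 `O=C1Cc2cc(S(=O)(=O)N3CCN(c4ccc(Br)cc4)CC3)ccc2N1` has not yet been measured in this assay. It differs from compound 3 in one place: bromo in place of fluoro on an aromatic carbon. Among the measured compounds shown here, no step between measured compounds is available to anchor this change, and compound 3 has no number from which the size of the step could be read. The expectation is that compound 4 stays close to where compound 3 stands, with any movement toward measurable inhibition modest and uncertain. Compound 4 is expected to give about 12000 nM in this assay, within a range from 3000 nM to 50000 nM, and there is a fair chance that again no number is returned.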

Compound 4, half-maximal inhibitory concentration: "not active" (no number reported)
For compound 4 the study gives words and no number; there is nothing to compare the estimate with.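

In this assay compound 3 gives "not active" (no number reported) and compound 4 gives "not active" (no number reported), so no step can be read between them. The compounds shown leave open whether 4-fluorophenyl to 4-bromophenyl changes inhibition at all. Nothing shown bears on this result.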